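A Cycloheptyl Ring in Place of a Branched Chain

The compounds below may be only part of what the source reports. "The series", "measured", "known", "first", "only" and "open" are said of these compounds alone.

Compound 3 `CCC(C)(CC)Cc1cnc(CCc2ccc(-c3ccccc3C(=O)O)cc2)[nH]1` gives 30 nM in an in vitro functional assay on cells for agonist activity at Bombesin receptor subtype-3 (Mus musculus), read by luminescence and calcium flux (on this read-out higher numbers stand for an effect only at larger amounts of compound and lower numbers for an effect already at smaller amounts), the second highest of the three numbers measured. Compound 1 `O=C(O)c1ccccc1-c1ccc(CCc2ncc(Cc3cccc(F)c3)[nH]2)cc1` gives 7.9 nM and compound 2 `O=C(O)c1ccccc1-c1ccc(CCc2ncc(-c3ccccc3)[nH]2)cc1` gives 872 nM in this assay. Compound 4 `O=C(O)c1ccccc1-c1ccc(CCc2ncc(CC3CCCCCC3)[nH]2)cc1` has not been measured; it differs from compound 3 by cycloheptyl in place of 1-ethyl-1-methylpropyl on a saturated chain carbon bound to an aromatic carbon. Among the measured compounds shown here, two measured steps touch the same position: a 3.8-fold higher number from compound 1 to compound 3 (0.58 log units; beyond the scatter) and a 29-fold lower number from compound 2 to compound 3 (1.46 log units; beyond the scatter), so an aromatic group there gave a lower number in one case and a much higher number in the other. Compound 4 is expected to stay close to compound 3, with a step of no change at the digits printed from compound 3 to compound 4 (within the scatter) in this assay, within the scatter. Compound 4 is estimated at 30 nM, between 10 nM and 100 nM.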

Compound 4, half-maximal effective concentration: 5.7 nM
The estimate for compound 4 lay 5.3-fold (0.72 log units) above the measured number, outside the stated range (below it).
By their numbers in this assay, from the lowest: compounds 4 and 1 (each within the scatter of the next); then compound 3; then compound 2.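

A ring matters at this place: in this assay there is a 5.3-fold lower number from compound 3 to compound 4 (0.72 log units; beyond the scatter) when cycloheptyl replaces the open 1-ethyl-1-methylpropyl on a saturated chain carbon bound to an aromatic carbon. An aromatic ring is not required there, as a 1.4-fold lower number from compound 1 to compound 4 (0.14 log units; within the scatter) appears when cycloheptyl replaces 3-fluorophenyl. There is also a 150-fold lower number from compound 2 to compound 4 (2.18 log units; beyond the scatter) when cycloheptylmethyl replaces phenyl on an aromatic carbon.

Going by these compounds, whether cyclopentyl, or a seven-membered ring containing an amine nitrogen, would fare as well remains open. Nothing available here explains why the ring and the branched chain differ.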